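Thiazol-2-yl Replaces 4-Cyanophenyl on the Benzylic Carbon

A few compounds are considered here, and "the series" means these few. Any claim that something is new, unique, unknown or untested is made for them only; others in the source may bear on it.

Compound 2 `N#Cc1ccc(C(c2ccccc2)N2CCN(c3ncnc4c3cnn4-c3ccccc3)CC2)cc1` carries a 4-cyanophenyl on a saturated chain carbon bound to an amine nitrogen in a ring and an aromatic carbon. In a functional assay on cells (Rhabdomyosarcoma cell, Homo sapiens) for cytotoxicity (a lower number here means a stronger inhibitor, a higher number a weaker inhibitor), compound 2 gives only a limit, > 25000 nM. Compound 1 `c1ccc(C(c2ccccn2)N2CCN(c3ncnc4c3cnn4-c3ccccc3)CC2)cc1` also gives only a limit in this assay, > 25000 nM. For the measured compounds named here, the single measured step, a step that the two limits leave unreadable from compound 1 to compound 2, cannot be sized because the limit of > 25000 nM in this assay, at which 2 of the 2 values shown sit, covers both values.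

Compound 3 `c1ccc(C(c2nccs2)N2CCN(c3ncnc4c3cnn4-c3ccccc3)CC2)cc1` is obtained from compound 2 by 1,3-thiazol-2-yl in place of 4-cyanophenyl on a saturated chain carbon bound to an amine nitrogen in a ring and an aromatic carbon. Going by the values given here, no measured step involves a thiazol-2-yl, and the only step at hand is unreadable, so it gives no direction for this assay. Compound 3 is therefore expected to remain at the limit in this assay, with an estimate of 40000 nM spanning 12000 nM to 150000 nM. This expected change, a step that the limit leaves unreadable from compound 2 to compound 3, is no step beyond the scatter.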

Compound 3, half-maximal inhibitory concentration: > 25000 nM
Compound 3 ended at the assay's limit (the forecaster's own chance of this, stated with the estimate: 85%); the middle value is on the limit's open side.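

Compound 3 also gives only a limit, so no new step can be read among compound 1, compound 2 and compound 3, because all three sit at the same limit: the limit of > 25000 nM in this assay, at which 3 of the 3 values shown sit.

The compounds shown leave open whether pyridin-2-yl, 4-cyanophenyl or 1,3-thiazol-2-yl on this carbon makes any difference in this assay.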